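Chlorines Return to the Phenyl Ring

The source may hold more compounds than are shown below. What is called first, only, known or untested is meant among the compounds shown, and "the series" means these compounds.

Three compounds share one core and differ only in the aromatic ring attached to the carbon that carries a double bond to nitrogen. Compound 1 `CN(C)CCn1cnnc1-c1cc(Oc2ccc(NC(=O)N/N=C/c3c(Cl)cccc3Cl)cc2F)ccn1` bears a 2,6-dichlorophenyl there, compound 2 `CN(C)CCn1cnnc1-c1cc(Oc2ccc(NC(=O)N/N=C/c3ccc(O)c(Br)c3)cc2F)ccn1` a 3-bromo-4-hydroxyphenyl, and compound 3 `CN(C)CCn1cnnc1-c1cc(Oc2ccc(NC(=O)N/N=C/c3ccccc3)cc2F)ccn1` a plain phenyl. In a functional assay on NCI-H460 cells (Homo sapiens) for cytotoxicity, read by MTT assay, with a stated time of 72 h (a higher number here means a weaker inhibitor, a lower number a stronger inhibitor), compound 1 gives 350 nM, compound 2 gives 430 nM, and compound 3 gives 1780 nM. Compound 3 stands at the highest number of the three: the step of a 5.1-fold higher number from compound 1 to compound 3 (0.71 log units; beyond the scatter) and the step of a 4.1-fold higher number from compound 2 to compound 3 (0.62 log units; beyond the scatter) both lie beyond the scatter, while a 1.2-fold higher number from compound 1 to compound 2 (0.09 log units; within the scatter) does not.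

Compound 4 `CN(C)CCn1cnnc1-c1cc(Oc2ccc(NC(=O)N/N=C/c3cccc(Cl)c3Cl)cc2F)ccn1` differs from compound 3 in one place: 2,3-dichlorophenyl in place of phenyl on a carbon with a double bond to nitrogen. The step from compound 1 to compound 3 bears most directly on this change, since it exchanged a dichlorophenyl for the same plain phenyl, and it was modest in size. Going back to a dichlorophenyl, though in a different arrangement, is therefore expected to lower the number by a modest amount, with the expected step being a 4.0-fold lower number from compound 3 to compound 4 (0.60 log units; beyond the scatter). The estimate for compound 4 in this assay is 450 nM, with a likely range from 200 nM to 1100 nM.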

Compound 4, half-maximal inhibitory concentration: 72 nM
Estimate against measurement, compound 4: 6.3-fold (0.80 log units) above; the whole stated range lies above it.
By their numbers in this assay, from the lowest: compound 4; then compounds 1 and 2 (each within the scatter of the next); then compound 3.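

In this assay the arrangement of the chlorines matters at this position, not only their presence: 2,3-dichlorophenyl and 2,6-dichlorophenyl hold the same atoms, yet the step is a 4.9-fold lower number from compound 1 to compound 4 (0.69 log units; beyond the scatter). Putting 2,3-dichlorophenyl on the carbon with a double bond to nitrogen in place of phenyl gives a 25-fold lower number from compound 3 to compound 4 (1.39 log units; beyond the scatter), and replacing 3-bromo-4-hydroxyphenyl gives a 6.0-fold lower number from compound 2 to compound 4 (0.78 log units; beyond the scatter), so compound 4 is the strongest inhibitor of the four. Compound 1 and compound 2 could not be told apart, which makes compound 4 the first to show that substituted rings here can differ from one another.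

Nothing in the available data gives a reason for these differences. Also open, as far as these compounds go, is how a phenyl carrying one chlorine, a methoxy group or an amine would compare with compound 4.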